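The compounds below may be only part of what the source reports. "The series", "measured", "known", "first", "only" and "open" are said of these compounds alone.

Compounds measured in an assay on microsomes from intestine for inhibition of acyl-CoA:cholesterol acyltransferase (Oryctolagus cuniculus); on this read-out lower numbers stand for stronger inhibition and higher numbers for weaker inhibition:
- compound 1, `CC(C)c1cccc(C(C)C)c1OC(=O)NC(=O)SCCc1ccccc1`: 880 nM
- compound 2, `CCCCCCCCCCCSC(=O)NC(=O)Oc1c(C(C)C)cccc1C(C)C`: 210 nM

Among the compounds with values here, compound 2 has the lowest number of the two; the only comparison is the step of a 4.2-fold lower number from compound 1 to compound 2 (0.62 log units; beyond the scatter), which is the sole structural change documented so far.

Compound 3, `CCCCCCCCCCCCSC(=O)NC(=O)Oc1c(C(C)C)cccc1C(C)C`, is not yet measured. It differs from compound 2 by methyl in place of hydrogen on a saturated chain carbon, ten or more bonds along the chain from a sulfur; the same difference, cut one bond further out, reads methyl to ethyl, ethyl to propyl, propyl to butyl.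

Within the data shown here, no measured step exchanges hydrogen for methyl on the saturated chain, so nothing directly bears on this change. Among the measured compounds shown here, the only step on this chain, phenyl to nonyl, is a larger alteration than the one at hand; it does not carry over. For compound 3 the step of a 1.2-fold lower number from compound 2 to compound 3 (0.07 log units; within the scatter) is therefore expected to stay within the scatter in this assay. Compound 3 is estimated at 180 nM, with a range from 80 nM to 420 nM.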

Compound 3, half-maximal inhibitory concentration: 16 nM
For compound 3 the middle estimate is 11-fold (1.05 log units) above the measured one; the measured number lies below the stated range.
By their numbers in this assay, from the lowest: compound 3; then compound 2; then compound 1.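

In this assay, methyl in place of hydrogen on a saturated chain carbon, ten or more bonds along the chain from a sulfur, is far from a silent change: it gives a 13-fold lower number from compound 2 to compound 3 (1.12 log units; beyond the scatter), a large step from a single added carbon. The far end of the chain therefore still registers on this read-out, and decyl in place of phenyl gives a 55-fold lower number from compound 1 to compound 3 (1.74 log units; beyond the scatter), also large, where nonyl in place of phenyl gave only the modest 4.2-fold lower number from compound 1 to compound 2 (0.62 log units; beyond the scatter). No measured information accompanies these compounds to explain the size of the new step.

As far as these compounds go, with only two saturated chains to compare, it remains open whether the numbers keep falling as the chain grows or reach a turning point. A longer chain would settle this, and a chain ending in a carboxylic acid or an amine would show how much the far end tolerates.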